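Swapping an Ester for an Amide: Expected Effect on Cytotoxicity

The source may hold more compounds than are shown below. What is called first, only, known or untested is meant among the compounds shown, and "the series" means these compounds.

- compound 1 `CCOC(=O)c1noc2c1CN(C(=O)c1cc(C(C)C)c(O)cc1O)CC2` gives 563 nM in an ADME assay on L6 cells (Rattus norvegicus) for cytotoxicity; on this read-out higher numbers stand for weaker inhibition and lower numbers for stronger inhibition
- compound 2 `CCNC(=O)c1nnn(-c2cc(C(C)C)c(O)cc2O)c1-c1ccc(CC2CCCC2)cc1` gives 8 nM in this assay

Compound 1 holds the higher of these two numbers, which here means weaker inhibition. The gap to compound 2 lies well beyond the usual scatter. Compound 3 `CCNC(=O)c1noc2c1CN(C(=O)c1cc(C(C)C)c(O)cc1O)CC2` keeps the core of compound 1 and changes one group, with ethylamino in place of ethoxy on a carbonyl carbon. This turns an ethoxycarbonyl into an ethylcarbamoyl. For the measured compounds named here, no measured pair shows this exchange on its own, so the size of the step is a judgement with little to lean on. Going by the values given here, the only hint is that compound 2 also carries ethylcarbamoyl and gives a low number (8 nM), though a single compound proves nothing about the group. In this assay the expected change is a 3.8-fold lower number from compound 1 to compound 3 (0.57 log units; beyond the scatter) (an estimate), a step beyond the scatter toward stronger inhibition. Compound 3 is expected at 150 nM within an estimated range of 30 nM to 800 nM on this read-out.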

Compound 3, half-maximal inhibitory concentration: 110 nM
For compound 3 the middle estimate is 1.4-fold (0.13 log units) above the measured one; the range from low to high includes it.
By their numbers in this assay, from the lowest: compound 2; then compound 3; then compound 1.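

In this assay, replacing ethoxy with ethylamino on a carbonyl carbon gives a 5.1-fold lower number from compound 1 to compound 3 (0.71 log units; beyond the scatter), a step beyond the scatter toward stronger inhibition. This shows that the read-out responds to the group on this carbonyl carbon, even when the rest of the core of compound 1 stays the same. The change is also a small one on paper, since both groups hold 3 heavy atoms and neither contains a ring, while ethylamino brings 1 hydrogen-bond donor where ethoxy has 0 hydrogen-bond donors, yet no measurement shown here explains why the number falls.

This single pair cannot show whether the hydrogen-bond donor matters, or whether the same exchange would have a similar effect on a different core. It also leaves open how the read-out would respond to other groups on this carbonyl carbon, such as a plain amine, a longer chain like butylamino, or a hydroxyl that would make the group a carboxylic acid.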